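Swapping the chlorophenyl for a methylphenyl group

The source may report more compounds than this note shows. Statements on the series, on what has been measured and on what is new or still open speak of the compounds shown alone.

Of the compounds shown here, three sharing one core have been tested in a functional assay on HCT-116 cells (Homo sapiens) for positive allosteric modulation, read by MTT assay, with stated times of 24 h and 48 h, tested at 2.5 uM; on this read-out higher numbers stand for more inhibition of growth at the one concentration tested and lower numbers for less inhibition of growth. Compound 1 `CS(=O)(=O)c1ccc(-c2cnc3[nH]cc(-c4nnc(-c5ccc(Cl)cc5)o4)c(=O)c3c2)cc1` gives 24.9% and stands lowest of the three. Compound 2 `N#Cc1ccc(-c2cnc3[nH]cc(-c4nnc(-c5ccc(Cl)cc5)o4)c(=O)c3c2)cc1` gives 35.4%, and compound 3 `O=c1c(-c2nnc(-c3ccc(Cl)cc3)o2)c[nH]c2ncc(-c3ccccc3)cc12` gives 29.8%. Among the measured steps, a number 10.5 percentage points higher from compound 1 to compound 2 (beyond the scatter) is the only one beyond the scatter, while a number 4.9 percentage points higher from compound 1 to compound 3 (within the scatter) and a number 5.6 percentage points lower from compound 2 to compound 3 (within the scatter) are both within it.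

Compound 4 `Cc1cccc(-c2nnc(-c3c[nH]c4ncc(-c5ccc(S(C)(=O)=O)cc5)cc4c3=O)o2)c1` has not yet been measured. It differs from compound 1 in this way: 3-methylphenyl in place of 4-chlorophenyl on an aromatic carbon. The measured steps all concern the other aromatic ring of the core, the one carrying methylsulfonyl, cyano or hydrogen; none touches the ring where 3-methylphenyl now replaces 4-chlorophenyl. So no measured step bears directly on this change, and the known steps show that even changes at the other ring move the numbers only modestly or not beyond the scatter.

Without a directly comparable step, the expected step of a number 1.1 percentage points higher from compound 1 to compound 4 (within the scatter) is none beyond the scatter. Compound 4 is therefore estimated at 26%, within a range from 12% to 42%.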

Compound 4, percent growth inhibition at one concentration: 50.8%
Compound 4: middle estimate off by 24.8 percentage points, on the low side, outside the stated range (above it).
By their numbers in this assay, from the lowest: compounds 1, 3 and 2 (each within the scatter of the next, the first and the last beyond it); then compound 4.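

In this assay, the ring attached to the five-membered aromatic ring with 2 nitrogen and 1 oxygen proves to be a place where a change can matter: a number 25.9 percentage points higher from compound 1 to compound 4 (beyond the scatter). Going by these compounds alone, that step is larger than the biggest step seen at the other aromatic ring, a number 10.5 percentage points higher from compound 1 to compound 2 (beyond the scatter), so the earlier compounds gave no sign of how much this position could move the number. The change is also subtle by the simple counts, since 4-chlorophenyl and 3-methylphenyl each have 7 heavy atoms and neither has hydrogen-bond donors or acceptors, and no measurement at hand explains the rise.

This single step swaps chlorine for methyl and also changes where the group is attached on the phenyl ring, so the two changes cannot be told apart; 4-methylphenyl and 3-chlorophenyl would separate them. Going by these compounds, it also remains open whether 3-methylphenyl gives a similar rise alongside the cyano or hydrogen of compound 2 and compound 3, and how an amine or a carboxylic acid on this phenyl ring would behave.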